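The compounds below may be only part of what the source reports. "The series", "measured", "known", "first", "only" and "open" are said of these compounds alone.

In a functional assay on Hs-578T cells (Homo sapiens) for inhibition, read by sulforhodamine B assay, with a stated time of 48 h (a lower number here means a stronger inhibitor of growth, a higher number a weaker inhibitor of growth), compound 1 `N#Cc1c(-c2nnc(O)c3nn(-c4ccccc4)cc23)nn(-c2ccccc2)c1-c1ccccc1` gives 46800 nM and compound 2 `N#Cc1c(-c2nnc(-c3ccccc3)c3nn(-c4ccccc4)cc23)nn(-c2ccccc2)c1-c1ccccc1` gives 31800 nM as its number, so these two lie within the usual scatter of each other. Compound 3 `Cc1ccc(-n2cc3c(-c4nn(-c5ccccc5)c(-c5ccccc5)c4C#N)nnc(-c4ccccc4)c3n2)cc1` differs from compound 2 by methyl in place of hydrogen on an aromatic carbon in one place, with methyl in place of hydrogen on an aromatic carbon. For the measured compounds named here, the single measured step of a 1.5-fold lower number from compound 1 to compound 2 (0.17 log units; within the scatter) stayed within the scatter and involves a different change, so it offers only weak guidance here. No shift beyond the scatter, in either direction, is therefore expected in this assay for this change. The estimated step of a 1.1-fold lower number from compound 2 to compound 3 (0.03 log units; within the scatter) lies within the scatter. Compound 3 is expected to give 30000 nM with 14000 nM to 60000 nM as the likely range.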

Compound 3, concentration for 50% growth inhibition: 38600 nM
Compound 3: middle estimate off by 1.3-fold (0.11 log units), on the low side; the measured number falls inside the stated range.
By their numbers in this assay, from the lowest: compounds 2, 3 and 1 (each within the scatter of the next).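

In this assay the change from phenyl to 4-methylphenyl gives a 1.2-fold higher number from compound 2 to compound 3 (0.08 log units; within the scatter) and so stays within the scatter. For the compounds shown here, the earlier step concerned a different place, so this is the first evidence that a methyl can sit on this six-membered aromatic ring of carbon only, para to a large group, without a shift beyond the scatter. Nothing available explains this result. From the compounds shown here alone, whether an amine, a carboxylic acid or a longer chain in place of the methyl would move the number beyond the scatter remains open.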